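Swapping phenyl for methyl on a weak neuroblastoma cell inhibitor

A few compounds are considered here, and "the series" means these few. Any claim that something is new, unique, unknown or untested is made for them only; others in the source may bear on it.

Three compounds sharing a related core were tested in a functional assay on SK-N-SH cells (Homo sapiens) for inhibition, read by sulforhodamine B assay, with a stated time of 48 h; a lower number here means a stronger inhibitor, a higher number a weaker inhibitor. Compound 2 `CO[C@@H]1CC=C2NN(c3cc4ccccc4[nH]3)C(=O)C[C@]2(c2ccccc2)O1` gives 9100 nM, and compound 1 `CO[C@@H]1CC=C2NN(c3cc4ccccc4[nH]3)C(=O)C[C@]2(C)O1` gives 19500 nM; the change between them is methyl in place of phenyl on a saturated ring carbon, and the step of a 2.1-fold higher number from compound 2 to compound 1 (0.33 log units; beyond the scatter). Compound 3 `COc1cc(OC)cc(N2NC3=CC[C@@H](OC)O[C@@]3(c3ccccc3)CC2=O)c1` gives 19500 nM, level with compound 1; the difference between the cores of compound 2 and compound 3 is not broken down here. Compound 4 `COc1cc(OC)cc(N2NC3=CC[C@@H](OC)O[C@@]3(C)CC2=O)c1` differs from compound 3 by methyl in place of phenyl on a saturated ring carbon. This is the same kind of change as that from compound 2 to compound 1, though the surroundings are described differently: on a saturated ring carbon of a six-membered non-aromatic ring with 2 nitrogen rather than one with 1 oxygen. The step for compound 4 is expected to resemble the earlier one, a 1.9-fold higher number from compound 3 to compound 4 (0.29 log units; within the scatter), because compound 3 starts at 19500 nM. Compound 4 is therefore estimated at 38000 nM, between 15000 nM and 90000 nM.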

Compound 4, half-maximal inhibitory concentration: 23700 nM
Beside the measured number, compound 4's estimate is 1.6-fold (0.21 log units) above it; low and high end bracket the measured number.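

In this assay the same swap of phenyl for methyl on the core of compound 3 gives a 1.2-fold higher number from compound 3 to compound 4 (0.08 log units; within the scatter) and so no clear change on this core. The two steps cannot be told apart: the same change on two cores in this assay, a 2.1-fold higher number (0.33 log units; beyond the scatter) from compound 2 to compound 1 and a 1.2-fold higher number (0.08 log units; within the scatter) from compound 3 to compound 4, 1.8-fold (0.25 log units) apart, within the scatter of two such steps. The swap therefore shows no measurable dependence on the core, yet two pairs, one of them within the scatter, do not prove that the step is the same size on both cores or that it would hold on a third.

The compounds shown leave open how other groups on that saturated ring carbon would fare, such as an ethyl group, a longer chain, an amine or a carboxylic acid. They also leave open whether any such group could make these weak inhibitors much stronger.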